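Butyl in Place of Isopropyl on the Shared Core

The source may hold more compounds than are shown below. What is called first, only, known or untested is meant among the compounds shown, and "the series" means these compounds.

Of the compounds shown here, two sharing one core have been measured in an assay on isolated protein (urine) for inhibition of Myeloperoxidase (Homo sapiens), read by spectrophotometry; a higher number here means a weaker inhibitor, a lower number a stronger inhibitor. Compound 1 `COc1c2ccccc2nn1C(C)C` gives 704 nM in this assay. Compound 2 `COCCOc1c2ccccc2nn1C(C)C` gives 1400 nM in this assay. Among the measured compounds shown here, the one step measured so far, a 2.0-fold higher number from compound 1 to compound 2 (0.30 log units; within the scatter), lies within the scatter, so compound 1 stands alongside compound 2 with no real separation between the two numbers.

Compound 3 `CCCCn1nc2ccccc2c1OC` is not yet measured. It differs from compound 1 at another part of the molecule: butyl in place of isopropyl on an aromatic nitrogen. For the measured compounds named here, no measured step touches the chain on the ring nitrogen, so the data give no direct guidance for this change. Going by the values given here, the only step available, from compound 1 to compound 2, was within the scatter and concerns a different place, leaving no reason to expect a large shift. The expected step in this assay is therefore small, a 1.1-fold higher number from compound 1 to compound 3 (0.06 log units; within the scatter), with no definite direction. Compound 3 is expected to give about 800 nM in this assay, estimated between 300 nM and 2500 nM.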

Compound 3, half-maximal inhibitory concentration: 910 nM
The estimate for compound 3 lay 1.1-fold (0.06 log units) below the measured number; measured number inside the range.
By their numbers in this assay, from the lowest: compounds 1, 3 and 2 (each within the scatter of the next).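

Replacing isopropyl with butyl on the aromatic nitrogen gives a 1.3-fold higher number from compound 1 to compound 3 (0.11 log units; within the scatter) in this assay. Among the compounds shown here, this is the first measured change to the chain at this position, and it shows that, for this pair, going from 3 carbon atoms to 4 leaves compound 1 and compound 3 indistinguishable in this assay. No supporting measurement is available to explain why the two numbers stay so close.

As far as these compounds go, a single pair cannot show how far this tolerance extends, so it remains open whether a longer chain, or a butyl chain ending in an amine or a carboxylic acid, would also leave the number within the scatter. From the compounds shown here alone, it is also open whether butyl on the nitrogen would behave the same way when combined with the methoxymethyl change seen in compound 2.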